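The compounds below may be only part of what the source reports. "The series", "measured", "known", "first", "only" and "open" are said of these compounds alone.

Measured so far:
- compound 1, `CCCCCCCCCCCCCCCCCCCCCCOC(=O)NC(CCC(=O)O)(CCC(=O)O)CCC(=O)O`: 360000 nM
- compound 2, `CCCCCCCCCCCCCCCCNC(=O)NC(CCC(=O)O)(CCC(=O)O)CCC(=O)O`: 350000 nM

In an ADME assay on cells (Epithelial cell, Homo sapiens) for cytotoxicity, read by MTT assay (on this read-out higher numbers stand for an effect only at larger amounts of compound and lower numbers for an effect already at smaller amounts), compound 1 gives 360000 nM and stands with the highest of the two numbers, though compound 2 at 350000 nM lies within the scatter of it, so the two read as one level. Within the data shown here, no step between measured compounds is available for the change in question; the two values only show that a carbamate with a long chain and a urea with a long chain sit at the same level of this assay.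

The next compound is compound 3, `CCCCCCCCCCCCCCCCCCCCOC(=O)NC(CCC(=O)O)(CCC(=O)O)CCC(=O)O`. From compound 1 it differs by hydrogen in place of ethyl on a saturated chain carbon, ten or more bonds along the chain from an oxygen next to a carbonyl group. Among the measured compounds shown here, with no measured step of this kind, the shortening of the chain is expected to move the number in this assay by little, no step beyond the scatter: a 1.0-fold lower number from compound 1 to compound 3 (0.01 log units; within the scatter). Compound 3 is therefore expected at 350000 nM, within a range from 180000 nM to 700000 nM.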

Compound 3, half-maximal effective concentration: 280000 nM
Compound 3: the middle estimate sits 1.3-fold (0.10 log units) above what was measured, within the range that was stated.
By their numbers in this assay, from the lowest: compounds 3, 2 and 1 (each within the scatter of the next).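

In this assay, hydrogen in place of ethyl on a saturated chain carbon, ten or more bonds along the chain from an oxygen next to a carbonyl group, gives a 1.3-fold lower number from compound 1 to compound 3 (0.11 log units; within the scatter). Among these compounds, this is the first step read at this position, and it shows that this change in the carbamate chain leaves the number within the scatter, so compound 1 and compound 3 read as one level. No measured finding bears on this result, so nothing can be said about its cause.

One small change at one position cannot describe the wider chain. Still open, on these data alone, is whether a much shorter chain, a longer chain, or an amine or a phenyl ring at this position would move the number beyond the scatter.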